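Swapping Bromo for Chloro on Two Related Cores

The compounds below may be only part of what the source reports. "The series", "measured", "known", "first", "only" and "open" are said of these compounds alone.

Measured compounds:
compound 1, `CCN(CC)CN1C(=O)/C(=N\c2nc3ccc(C)cc3s2)c2c(Br)cccc21`: 16100 nM
compound 2, `O=C1C(=O)N(CN2CCCCC2)c2cccc(Br)c21`: 66900 nM
compound 3, `O=C1C(=O)N(CN2CCCCC2)c2cccc(Cl)c21`: 70700 nM

All three were tested in an ADME assay on MCF-10A cells (Homo sapiens) for cytotoxicity, read by sulforhodamine B assay, with a stated time of 48 h; on this read-out lower numbers stand for stronger inhibition of growth and higher numbers for weaker inhibition of growth. Compound 1 gives the lowest of the three numbers; compound 2 lies a good way higher, and compound 3 higher still, both gaps beyond the scatter. How the core of compound 1 differs from that of compound 2 is not broken down here.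

Compound 2 and compound 3 differ in one place: chloro in place of bromo on an aromatic carbon. That change made a 1.1-fold higher number from compound 2 to compound 3 (0.02 log units; within the scatter). Compound 4, `CCN(CC)CN1C(=O)/C(=N\c2nc3ccc(C)cc3s2)c2c(Cl)cccc21`, is not yet measured; it differs from compound 1 by the same change, (chloro in place of bromo on an aromatic carbon), at a place described in identical words.

Among the measured compounds shown here, since the one measured instance of this change, from compound 2 to compound 3, stayed within the scatter, compound 4 is expected to sit close to compound 1, with an estimated step of a 1.1-fold higher number from compound 1 to compound 4 (0.02 log units; within the scatter). This rests on a single pair, so the range is kept wide. For compound 4 the expected value in this assay is 17000 nM, estimated to lie between 8000 nM and 36000 nM.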

Compound 4, concentration for 50% growth inhibition: 43900 nM
Compound 4: middle estimate off by 2.6-fold (0.41 log units), on the low side; the whole stated range lies below it.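

On the core of compound 1, chloro in place of bromo on an aromatic carbon gave a 2.7-fold higher number from compound 1 to compound 4 (0.44 log units; beyond the scatter) in this assay. Set beside the same change on the core of compound 2, the two steps are no further apart than the scatter of two such steps allows: the same change on two cores in this assay, a 1.1-fold higher number (0.02 log units; within the scatter) from compound 2 to compound 3 and a 2.7-fold higher number (0.44 log units; beyond the scatter) from compound 1 to compound 4, 2.6-fold (0.41 log units) apart, within the scatter of two such steps The change can therefore be read as carrying across these two cores without a demonstrated difference, although only the step on the core of compound 1 lies beyond the scatter; this does not show that the step is the same on both cores, and two pairs cannot fix its size on any other core.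

The compounds shown leave open how a fluoro, methyl or methoxy group on the same aromatic carbon would compare with bromo and chloro. They also leave open whether a step of this kind would appear on a core with a carboxylic acid or a longer chain in place of the present amine side chains.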